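The source may report more compounds than this note shows. Statements on the series, on what has been measured and on what is new or still open speak of the compounds shown alone.

In a functional assay on PC-3 cells (Homo sapiens) for cytotoxicity, read by MTT assay, with a stated time of 72 h (on this read-out lower numbers stand for stronger inhibition and higher numbers for weaker inhibition), compound 3 (`COc1cc2ncnc(Nc3ccc(F)c(Cl)c3)c2cc1NC(=O)N/N=C/c1ccc(O)c(Br)c1`) gives 15300 nM. Compound 2 (`COc1cc2ncnc(Nc3ccc(F)c(Cl)c3)c2cc1NC(=O)N/N=C/c1cccc(Cl)c1Cl`) gives 24400 nM, within the scatter of compound 3, while compound 1 (`O=C(N/N=C/c1cc(Br)c(O)c(Br)c1)Nc1cc2c(Nc3ccc(F)c(Cl)c3)ncnc2cc1O[C@H]1CCOC1`) gives 6160 nM, a lower number beyond the scatter of compound 3. Compound 4 (`COc1cc2ncnc(Nc3ccc(F)c(Cl)c3)c2cc1NC(=O)N/N=C/c1cc(Br)c(O)c(Br)c1`) departs from compound 3 by one change: bromo in place of hydrogen on an aromatic carbon, giving 3,5-dibromo-4-hydroxyphenyl. Going by the values given here, the only measured step at this end, a 1.6-fold lower number from compound 2 to compound 3 (0.20 log units; within the scatter), stays within the scatter and is a different exchange. Compound 1 carries the same 3,5-dibromo-4-hydroxyphenyl at 6160 nM but differs elsewhere from compound 4, so it offers only a weak hint toward lower numbers. The expected change is a 1.4-fold lower number from compound 3 to compound 4 (0.14 log units; within the scatter), within the scatter. The estimate for compound 4 is 11000 nM, with an expected range of 5000 nM to 24000 nM.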

Compound 4, half-maximal inhibitory concentration: 41500 nM
Beside the measured number, compound 4's estimate is 3.8-fold (0.58 log units) below it, and the stated range ends below it.
By their numbers in this assay, from the lowest: compound 1; then compounds 3, 2 and 4 (each within the scatter of the next, the first and the last beyond it).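

In this assay, going by these compounds alone, bromo at this position, ortho to a hydroxy group, gives a 2.7-fold higher number from compound 3 to compound 4 (0.43 log units; beyond the scatter) and so the first step beyond the scatter. 3,5-Dibromo-4-hydroxyphenyl in place of 2,3-dichlorophenyl gives only a 1.7-fold higher number from compound 2 to compound 4 (0.23 log units; within the scatter) and thus no readable change. With 3,5-dibromo-4-hydroxyphenyl held constant, methyl in place of oxolan-3-yl on the oxygen gives a 6.7-fold higher number from compound 1 to compound 4 (0.83 log units; beyond the scatter) and places the low number of compound 1 with the oxolan-3-yl group, not with the second bromo.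

No available evidence accounts for the rise with bromo. On these data alone, whether an amine or a methoxy group at this position would follow bromo remains open.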